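Ethyl in Place of Phenyl: What to Expect

The source may hold more compounds than are shown below. What is called first, only, known or untested is meant among the compounds shown, and "the series" means these compounds.

In a functional assay on WM-115 cells (Homo sapiens) for inhibition, read by fluorescence and SYBR Green assay (on this read-out lower numbers stand for an effect already at smaller amounts and higher numbers for an effect only at larger amounts of compound), compound 1 (`N=C(NCCCCCCCN)c1ccc(OCCCCCCCCOc2ccc(C(=N)NCCCCCCCN)cc2)cc1`) gives 45800 nM and compound 2 (`N=C(N)c1ccc(OCCCN(CCCOc2ccc(C(=N)N)cc2)Cc2ccccc2)cc1`) gives 41000 nM which lies within the usual scatter of compound 1. Compound 3 (`CCCN(CCCOc1ccc(C(=N)N)cc1)CCCOc1ccc(C(=N)N)cc1`) has not been measured yet and differs from compound 2 by ethyl in place of phenyl on a saturated chain carbon bound to an amine nitrogen with ethyl in place of phenyl on a saturated chain carbon bound to an amine nitrogen. Among the compounds with values here, no measured pair shows this change, so the estimated step of a 1.2-fold higher number from compound 2 to compound 3 (0.09 log units; within the scatter) is expected to stay within the scatter, with no firm direction. In this assay compound 3 is estimated at 50000 nM with 20000 nM to 120000 nM as the expected range.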

Compound 3, half-maximal effective concentration: 500000 nM
Compound 3: middle estimate off by 10-fold (1.00 log units), on the low side, and the stated range ends below it.
By their numbers in this assay, from the lowest: compounds 2 and 1 (each within the scatter of the next); then compound 3.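

Putting ethyl in place of phenyl on a saturated chain carbon bound to an amine nitrogen is no silent swap: in this assay it gives a 12-fold higher number from compound 2 to compound 3 (1.09 log units; beyond the scatter) and so shows that this position responds strongly to what sits on it. The benzyl compound 2 acts at smaller amounts than the propyl compound 3. Nothing available explains this step.

This single pair cannot separate losing the ring from losing carbon atoms. A cyclohexyl group or a longer chain such as hexyl in the same place would tell these two apart.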